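This account rests on a few compounds, and the source may have more. Where it says the series, first, only, none or still open, it means among the compounds named here.

Measured so far:
compound 1 `Cc1ccc(S(=O)(=O)NCc2ccc(CNC(=O)c3ccc(F)cc3)cc2)cc1` — 75%
compound 2 `O=C(NCc1ccc(CNS(=O)(=O)c2ccccc2)cc1)c1ccc(F)cc1` — 40%

In a functional assay on the whole organism for inhibition, with Mus musculus as the target, with stated times of 30 min and 2 h, at a dose of 10 mg/kg by the intraperitoneal route (on this read-out higher numbers stand for more inhibition at the one dose given (going by the name of the read-out) and lower numbers for less inhibition), compound 1 gives 75%, the higher of the two numbers shown; compound 2 gives 40%. Within the data shown here, the only measured step, a number 35 percentage points lower from compound 1 to compound 2 (beyond the scatter), is a change at the sulfonamide end, hydrogen in place of methyl on an aromatic carbon, and it is large and beyond the scatter.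

Compound 3 `COc1cccc(C(=O)NCc2ccc(CNS(=O)(=O)c3ccc(C)cc3)cc2)c1` differs from compound 1 at the other end of the shared core: 3-methoxyphenyl in place of 4-fluorophenyl on a carbonyl carbon. Among the measured compounds shown here, no measured step touches the aryl group on the carbonyl carbon, so the one step known does not bear on this change and gives no direction for it. The working assumption is that the change leaves the number near that of compound 1, with wide uncertainty on either side. The estimated step is a number 15 percentage points lower from compound 1 to compound 3 (beyond the scatter). For compound 3 the expected value is 60%, with a range from 30% to 85%.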

Compound 3, a percentage reported as inhibition, in the whole organism at one dose (the size of the read-out at that dose, not a potency): 28%
Compound 3: the middle estimate sits 32 percentage points above what was measured, and the stated range ends above it.
By their numbers in this assay, from the lowest: compound 3; then compound 2; then compound 1.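

In this assay, the aryl group on the carbonyl carbon is not a silent position on the shared core: 3-methoxyphenyl in place of 4-fluorophenyl gives a number 47 percentage points lower from compound 1 to compound 3 (beyond the scatter). Together with a number 35 percentage points lower from compound 1 to compound 2 (beyond the scatter), this places a large step at each of the two ends of the shared core, so the number responds to a change at either end in these compounds. Nothing available speaks to the reason for the new step.

On these data alone, whether 4-methoxyphenyl on the carbonyl carbon would hold the number of compound 1 stays open, so the methoxy group and its place on the ring remain unseparated. Also open, as far as these compounds go, is how a plain phenyl, or a ring carrying a carboxylic acid or an amine, would read at this position.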